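A few compounds are considered here, and "the series" means these few. Any claim that something is new, unique, unknown or untested is made for them only; others in the source may bear on it.

Within the data shown here, in an assay on HEK293 cells for displacement of a labelled ligand from prostaglandin D2 receptor 2 (Homo sapiens) (a lower number here means a stronger inhibitor, a higher number a weaker inhibitor), compound 1 `CCOC(=O)CCCSc1nc2ccccc2n1CC(=O)O` gives 4410 nM and compound 2 `Cc1ccc(CSc2nc3ccccc3n2CC(=O)O)cc1` gives 220 nM, the lowest of the two numbers; the only measured step is a 20-fold lower number from compound 1 to compound 2 (1.30 log units; beyond the scatter). Compound 3 `Cc1ccccc1CSc1nc2ccccc2n1CC(=O)O` differs from compound 2 by 2-methylphenyl in place of 4-methylphenyl on a saturated chain carbon bound to a sulfur. Among the measured compounds shown here, that one measured step exchanged a chain for an aryl group, so it says little about where the methyl sits on the aryl ring; no measured step bears directly on this change. A step within the scatter of this assay is therefore expected, a 1.4-fold higher number from compound 2 to compound 3 (0.13 log units; within the scatter). Compound 3 is estimated at 300 nM, with a range of 100 nM to 1000 nM.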

Compound 3, half-maximal inhibitory concentration: 810 nM
Compound 3: the middle estimate sits 2.7-fold (0.43 log units) below what was measured; the range from low to high includes it.
By their numbers in this assay, from the lowest: compound 2; then compound 3; then compound 1.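

In this assay the place of the methyl on the aryl group matters: 2-methylphenyl in place of 4-methylphenyl gives a 3.7-fold higher number from compound 2 to compound 3 (0.57 log units; beyond the scatter) and so shows that this site responds to more than the presence of an aryl group. Against 2-(ethoxycarbonyl)ethyl, 2-methylphenyl still gives a 5.4-fold lower number from compound 1 to compound 3 (0.74 log units; beyond the scatter), a smaller gain than 4-methylphenyl gives. No supporting evidence accounts for the gap between the two methylphenyl groups.

Open, on these data alone, is how a plain phenyl group would compare with either methylphenyl group. Also open, as far as these compounds go, is whether a chlorine atom on the ring would follow the same order.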